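A few compounds are considered here, and "the series" means these few. Any claim that something is new, unique, unknown or untested is made for them only; others in the source may bear on it.

In a functional assay on HCT-116 cells (Homo sapiens) for antiproliferative activity, read by MTT assay, with a stated time of 48 h (on this read-out higher numbers stand for weaker inhibition and lower numbers for stronger inhibition), compound 3 (`CCOc1ccc(Nc2c(-c3ccc(OC)cc3)c(=O)oc3cc(OC)ccc23)cc1`) gives 33000 nM and so lies within the scatter of compound 2 (`COc1ccc(-c2c(Nc3ccc(C)c(O)c3)c3ccc(OC)cc3oc2=O)cc1`) with 26500 nM and of compound 1 (`COc1ccc(-c2c(Nc3ccc(C)cc3)c3ccccc3oc2=O)cc1`) with 64800 nM on the numbers shown. Compound 4 (`COc1ccc(-c2c(Nc3ccc(C)cc3)c3ccc(OC)cc3oc2=O)cc1`) differs from compound 3 by one change (methyl in place of ethoxy on an aromatic carbon): methyl in place of ethoxy on an aromatic carbon, para to a large group. Among the compounds with values here, the one measured step on this same group (a 1.2-fold higher number from compound 2 to compound 3 (0.10 log units; within the scatter)) exchanged 3-hydroxy-4-methylphenyl for 4-ethoxyphenyl and stayed within the scatter. Compound 1 (64800 nM) already carries 4-methylphenyl on another core. No step beyond the scatter is therefore expected in this assay and the estimated move (a 1.1-fold higher number from compound 3 to compound 4 (0.04 log units; within the scatter)) has no firm direction. The expected value for compound 4 is 36000 nM (estimated range 19000 nM to 68000 nM).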

Compound 4, half-maximal inhibitory concentration: 82400 nM
Beside the measured number, compound 4's estimate is 2.3-fold (0.36 log units) below it; measured number outside the range, above it.
By their numbers in this assay, from the lowest: compounds 2, 3, 1 and 4 (each within the scatter of the next, the first and the last beyond it).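

In this assay the substituents on this ring do register: methyl in place of ethoxy gives a step beyond the scatter (a 2.5-fold higher number from compound 3 to compound 4 (0.40 log units; beyond the scatter)), and so does hydrogen in place of hydroxy (a 3.1-fold higher number from compound 2 to compound 4 (0.49 log units; beyond the scatter)), whereas the earlier exchange on this ring stayed within it. Methoxy in place of hydrogen on the core stays within the scatter (a 1.3-fold higher number from compound 1 to compound 4 (0.10 log units; within the scatter)). Nothing measured here gives a reason for these steps. As far as these compounds go, whether an amine, a carboxylic acid or a longer chain in place of ethoxy would shift the number further remains open.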